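Replacing a Free Sulfur with Methylselanyl on One Core

This account rests on a few compounds, and the source may have more. Where it says the series, first, only, none or still open, it means among the compounds named here.

Compound 1 `CSc1ccc(CNc2nc(SC)nc3ncccc23)cc1` and compound 3 `CCCCC[Se]c1nc(N)c2cccnc2n1` set the frame. In a functional assay on MCF7 cells (Homo sapiens) for cytotoxicity, read by MTT assay, with a stated time of 72 h (on this read-out higher numbers stand for lower toxicity in this test and lower numbers for higher toxicity in this test), compound 1 gives 9130 nM. In this assay compound 3 gives 85000 nM. Compound 2 `Sc1nc(NCc2ccccc2)c2ccccc2n1` stands apart from both. In this assay compound 2 gives only a limit of the assay, > 100000 nM. The evidence notes (the limit of > 100000 nM in this assay, at which 1 of the 3 values shown sits), so compound 2 has no place on the numerical scale and is known only to sit at that limit.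

Compound 4 `C[Se]c1nc(NCc2ccccc2)c2ccccc2n1` has not yet been measured in this assay. It differs from compound 2 in one place: a group of 2 heavy atoms (1 carbon, 1 selenium; no ring) in place of one sulfur atom, on an aromatic carbon. Among the compounds with values here, no measured pair in this set shares that change, so the step can only be expected from what surrounds it. Compound 3 carries a longer selenium-bearing chain on a different core and gives 85000 nM, and compound 1 with its own substituents gives 9130 nM; neither is a direct counterpart of compound 4.

The step from compound 2 to compound 4 is expected to be an at least 1.4-fold lower number from compound 2 to compound 4 (0.15 log units; that floor lies within the scatter), moving from a limit toward a measurable number. Compound 4 is estimated at 70000 nM, between 15000 nM and 200000 nM, with a real chance that the assay again reports only a limit.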

Compound 4, concentration lethal to 50% of the cells: > 100000 nM
Compound 4 gave a limit, no number; the forecaster's own chance of this, stated with the estimate: 40%; at least 1.4-fold (0.15 log units) between middle value and limit.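

In this assay compound 4 gives only a limit of the assay, > 100000 nM. Compound 2 is also known only as a limit, so no step can be read from compound 2 to compound 4: the limit of > 100000 nM in this assay, at which 2 of the 4 values shown sit.

The compounds shown leave open whether placing the selenium-bearing group where the sulfanyl group stood changes the value at all on the shared core.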